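Thiophen-3-yl for thiophen-2-yl, tested a second time

This account rests on a few compounds, and the source may have more. Where it says the series, first, only, none or still open, it means among the compounds named here.

Compound 1 `Oc1cccc(-c2cc(-c3ccccc3)cc(-c3cccs3)n2)c1` gives 17000 nM in a functional assay on HeLa cells (Homo sapiens) for cytotoxicity, read by ELISA, with a stated time of 2 days; on this read-out higher numbers stand for weaker inhibition and lower numbers for stronger inhibition. Compound 2 `Oc1cccc(-c2cc(-c3ccccc3)cc(-c3ccsc3)n2)c1` differs from it by thiophen-3-yl in place of thiophen-2-yl on an aromatic carbon, and in this assay compound 2 gives 13800 nM, a step of a 1.2-fold lower number from compound 1 to compound 2 (0.09 log units; within the scatter). Compound 3 `Oc1cccc(-c2cc(-c3ccccc3)nc(-c3cccs3)c2)c1` carries the same groups on a differently joined core; the difference between the two cores is not broken down here. In this assay compound 3 gives 15300 nM, within the scatter of the numbers for compound 1 and compound 2. Compound 4 `Oc1cccc(-c2cc(-c3ccccc3)nc(-c3ccsc3)c2)c1` differs from compound 3 by thiophen-3-yl in place of thiophen-2-yl on an aromatic carbon, the same kind of change as that from compound 1 to compound 2, at a place described in the same words. Because the earlier step was a 1.2-fold lower number from compound 1 to compound 2 (0.09 log units; within the scatter), the expected step is a 1.2-fold lower number from compound 3 to compound 4 (0.09 log units; within the scatter). Compound 4 is therefore estimated at 12500 nM, from 6000 nM to 26000 nM.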

Compound 4, half-maximal inhibitory concentration: 14900 nM
The estimate for compound 4 lay 1.2-fold (0.08 log units) below the measured number; the measured number falls inside the stated range.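

In this assay, the second test of the change gives a 1.0-fold lower number from compound 3 to compound 4 (0.01 log units; within the scatter), and it agrees with the first: the same change on two cores in this assay, a 1.2-fold lower number (0.09 log units; within the scatter) from compound 1 to compound 2 and a 1.0-fold lower number (0.01 log units; within the scatter) from compound 3 to compound 4, 1.2-fold (0.08 log units) apart, within the scatter of two such steps. On these two cores, then, swapping thiophen-2-yl for thiophen-3-yl leaves the number where it was, and that much carries from one core to the other. It does not show that a step of real size would carry across, as both steps here lie within the scatter, and two cores say nothing about others in the series.

The compounds shown leave open whether a different group in that place, such as an amine or a carboxylic acid, would move the number on either core. They also leave open whether such a step would then match between the two cores.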